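Benzyl in Place of Methyl on an Amide Nitrogen

This account rests on a few compounds, and the source may have more. Where it says the series, first, only, none or still open, it means among the compounds named here.

Compound 1 `CCCn1c(SCc2cc([N+](=O)[O-])ccc2OC)nc2cc(NC(=O)NC(C)(C)C)cc(C(=O)OC)c21`: 280 nM
Compound 2 `CCCn1c(SCc2cc([N+](=O)[O-])ccc2OC)nc2cc(NC(=O)NC(C)(C)C)cc(C(=O)NC)c21`: 23 nM

Among the measured compounds shown here, in an assay on isolated protein for inhibition of Gonadotropin-releasing hormone receptor (Rattus norvegicus) (on this read-out lower numbers stand for stronger inhibition and higher numbers for weaker inhibition), compound 2 stands lowest of the two numbers, and the only measured step, a 12-fold lower number from compound 1 to compound 2 (1.09 log units; beyond the scatter), concerns the group on a carbonyl carbon. Compound 3 `CCCn1c(SCc2cc([N+](=O)[O-])ccc2OC)nc2cc(NC(=O)NC(C)(C)C)cc(C(=O)NCc3ccccc3)c21` differs from compound 2 by phenyl in place of hydrogen on a saturated chain carbon bound to an amide-type nitrogen. For the measured compounds named here, no measured step touches this position, and the change leaves the amide itself in place. The step expected here, a 1.3-fold higher number from compound 2 to compound 3 (0.12 log units; within the scatter), is small and without a clear direction beyond the usual scatter. Compound 3 is therefore estimated at 30 nM, with a range from 8 nM to 120 nM.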

Compound 3, half-maximal inhibitory concentration: 130 nM
Beside the measured number, compound 3's estimate is 4.3-fold (0.64 log units) below it; the measured number lies above the stated range.
By their numbers in this assay, from the lowest: compound 2; then compound 3; then compound 1.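

Benzyl on the amide nitrogen is accepted but at a cost: in this assay, phenyl in place of hydrogen on this saturated chain carbon gives (a 5.7-fold higher number from compound 2 to compound 3 (0.75 log units; beyond the scatter)). The benzyl amide still keeps an edge over the ester (a 2.2-fold lower number from compound 1 to compound 3 (0.33 log units; beyond the scatter)), so the advantage of the amide over the ester depends on the group carried by its nitrogen. No supporting measurement bears on why the number rises. The compounds shown leave open how an ethyl or propyl chain on the amide nitrogen would behave. Such chains would help show whether the rise follows chain size or the phenyl ring itself.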